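Changing the Amide Side Chain of Compound 3

A few compounds are considered here, and "the series" means these few. Any claim that something is new, unique, unknown or untested is made for them only; others in the source may bear on it.

Compound 1 `CCn1c(C(=O)NCCN)ccc1C(CC)(CC)c1ccc(OCCC(O)(CC)CC)c(C)c1` gives 670 nM
Compound 2 `C#CC(C)OC(=O)c1ccc(C(CC)(CC)c2ccc(OCCC(O)(CC)CC)c(C)c2)n1CC` gives > 50000 nM which is a limit of the assay
Compound 3 `CCn1c(C(=O)NC(C)C(=O)O)ccc1C(CC)(CC)c1ccc(OCCC(O)(CC)CC)c(C)c1` gives 19700 nM

In a functional assay on MCF7 cells (Homo sapiens) for antiproliferative activity, read by MTT assay, with a stated time of 48 h (a lower number here means a stronger inhibitor, a higher number a weaker inhibitor), compound 3 gives 19700 nM and holds the higher of the two exact numbers, compound 1 having the other. Compound 2 has only a limit and no exact number.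

Compound 4 `CCn1c(C(=O)NC(CO)CCO)ccc1C(CC)(CC)c1ccc(OCCC(O)(CC)CC)c(C)c1` has not yet been measured. Its change from compound 3 is 3-hydroxy-1-(hydroxymethyl)propyl in place of 1-carboxyethyl on an amide-type nitrogen on the amide-type nitrogen. Among the measured compounds shown here, only one measured step changes this same place, and it is large: a 29-fold higher number from compound 1 to compound 3 (1.47 log units; beyond the scatter) for a swap of 2-aminoethyl to 1-carboxyethyl. Removing the 1-carboxyethyl might therefore win back part of that loss, though 3-hydroxy-1-(hydroxymethyl)propyl was not among the groups tested, so a moderate move is the cautious expectation. The expected step is a 3.3-fold lower number from compound 3 to compound 4 (0.52 log units; beyond the scatter) and it points to a lower number. For compound 4 the estimate in this assay is 6000 nM (expected range 1500 nM to 25000 nM).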

Compound 4, half-maximal inhibitory concentration: 31400 nM
Compound 4: middle estimate off by 5.2-fold (0.72 log units), on the low side, and the stated range ends below it.
By their numbers in this assay, from the lowest: compound 1; then compounds 3 and 4 (each within the scatter of the next). At a limit, above all of these: compound 2.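

Placing 3-hydroxy-1-(hydroxymethyl)propyl on the amide-type nitrogen in place of 1-carboxyethyl gives a 1.6-fold higher number from compound 3 to compound 4 (0.20 log units; within the scatter) in this assay so taking away the carboxylic acid and adding hydroxyl groups brings no measurable gain at this position. The side chain of compound 1 keeps its clear lead with a 47-fold higher number from compound 1 to compound 4 (1.67 log units; beyond the scatter) and among these amides only 2-aminoethyl stands apart. Compound 2 has only a limit, so the step of an at least 1.5-fold lower number from compound 2 to compound 4 (0.20 log units; that floor lies within the scatter) cannot be read as a true difference: the limit of > 50000 nM in this assay, at which 1 of the 4 values shown sits.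

Still open, going by these compounds, is whether the amine of the 2-aminoethyl group sets compound 1 apart, or rather the length of its chain. A 3-aminopropyl or a 2-hydroxyethyl group on the same amide-type nitrogen would help separate the two.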